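One added chloro on a measured scaffold

The source may hold more compounds than are shown below. What is called first, only, known or untested is meant among the compounds shown, and "the series" means these compounds.

compound 1 `Cc1cc(CN(CCC(F)(F)F)C(CC(=O)O)c2ccc(Cl)cc2)ccc1OCCN1C(=O)CCC1=O`: 81%
compound 2 `COc1cc(CN(CC(C)C)C(CC(=O)O)c2ccc(Cl)cc2)ccc1OCCN1C(=O)CCC1=O`: 80%

These values come from an ADME assay on liver (Homo sapiens) for metabolic stability, read by LC-MS, using microsomes and NADPH; on this read-out higher numbers stand for a more stable compound and lower numbers for a less stable compound. Compound 2, at 80%, lies within the usual scatter of compound 1, so the two cannot be told apart on this read-out.

Compound 3 `COc1cc(CN(CC(C)C)C(CC(=O)O)c2ccc(Cl)cc2Cl)ccc1OCCN1C(=O)CCC1=O` matches compound 2 except in one place: chloro in place of hydrogen on an aromatic carbon. The added chloro sits ortho to a large group and meta to a chloro group, so 4-chlorophenyl becomes 2,4-dichlorophenyl.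

Within the data shown here, no measured pair shows this change, so the expectation rests on little. Starting from compound 2 at 80%, a small drop or no change beyond the scatter is expected. The estimated change is a number 4 percentage points lower from compound 2 to compound 3 (within the scatter). For compound 3 the estimated value is 76%, with an expected range from 58% to 90%.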

Compound 3, percent of the compound remaining: 57%
For compound 3 the middle estimate is 19 percentage points above the measured one, and the stated range ends above it.
By their numbers in this assay, from the lowest: compound 3; then compounds 2 and 1 (each within the scatter of the next).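

In this assay, a chloro on the aromatic carbon ortho to a large group and meta to a chloro group, which turns 4-chlorophenyl into 2,4-dichlorophenyl, gives a number 23 percentage points lower from compound 2 to compound 3 (beyond the scatter). This position is therefore not a neutral spot on the ring: one added heavy atom is enough to move this read-out, which compound 1 and compound 2 could not show, as they differ in more than one place. Nothing given here explains why the compound becomes less stable with this change.

On these data alone, it stays open whether any group on this carbon would do the same, or whether this is particular to chloro; a fluoro on the same carbon would help to separate the two. Also open, as far as these compounds go, is whether the same added chloro would give a similar step on the core of compound 1.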